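Lengthening the amine chain of compound 2

The source may report more compounds than this note shows. Statements on the series, on what has been measured and on what is new or still open speak of the compounds shown alone.

Measured in a functional assay on HCT-116 cells (Homo sapiens) for cytotoxicity, read by MTT assay, with a stated time of 72 h; on this read-out higher numbers stand for weaker inhibition and lower numbers for stronger inhibition:
- Compound 1 `O=C(NCCCNc1c(C(=O)NCc2ccc(F)cc2)nc(Br)c2cccnc12)c1ccccc1`: > 10000 nM, a limit
- Compound 2 `NCCNc1c(C(=O)NCc2ccc(F)cc2)nc(Br)c2cccnc12`: > 20000 nM, a limit

Compound 2 gives > 20000 nM, which is a limit and not a number. For the measured compounds named here, the only other value available is also a limit, so there is no measured number to compare it with.

Compound 3 `NCCCCCCNc1c(C(=O)NCc2ccc(F)cc2)nc(Br)c2cccnc12` keeps the shared core of compound 2. In compound 3, 4-aminobutyl stands in place of amino on a saturated chain carbon, two bonds along the chain from a nitrogen on an aromatic ring (4-aminobutyl in place of amino on a saturated chain carbon, two bonds along the chain from a nitrogen on an aromatic ring). The same difference can be read as (2-aminoethyl)amino changing to (6-aminohexyl)amino.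

Going by the values given here, the only measured step at this place on the chain is a step that the two limits leave unreadable from compound 1 to compound 2, so it offers no size to carry over and no direction to follow. With nothing firmer to go on, no shift beyond the scatter is expected in this assay. The expected step is an at least 1.6-fold lower number from compound 2 to compound 3 (0.22 log units; that floor lies within the scatter), and this is only a cautious estimate. Compound 3 is expected at 12000 nM, with an estimated range of 3000 nM to 30000 nM.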

Compound 3, half-maximal inhibitory concentration: 7000 nM
For compound 3 the middle estimate is 1.7-fold (0.23 log units) above the measured one, and the stated range covers the measured number.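

In this assay, for the compounds shown here, compound 3 gives 7000 nM, the first value at this place on the chain that is a number and not a limit. Going from (2-aminoethyl)amino to (6-aminohexyl)amino, with the free amine kept at the chain end, brings an at least 2.8-fold lower number from compound 2 to compound 3 (0.45 log units; beyond the scatter), so this position does respond to chain length, and the direction is one the earlier pair could not show. The change of benzamido to 3-aminopropyl gives an at least 1.4-fold lower number from compound 1 to compound 3 (0.15 log units; that floor lies within the scatter), and a floor inside the scatter settles no order between these two compounds, so the result says more about chain length than about the benzamide cap.

With only a short chain and a long one to compare, the compounds shown leave open whether the number falls steadily with length or drops at one point, which a (4-aminobutyl)amino or an (8-aminooctyl)amino chain could help to tell. They also leave open whether the amine at the chain end matters at all, a question that a plain hexylamino chain or a chain ending in a carboxylic acid would address.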